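Pentyl for tolyl on a bromo-nitroquinolinone core

This account rests on a few compounds, and the source may have more. Where it says the series, first, only, none or still open, it means among the compounds named here.

Measured so far:
- Compound 1 `COc1ccc(Cn2c(-c3ccc(C)cc3)c(Br)c(=O)c3cc([N+](=O)[O-])ccc32)cc1`: 2430 nM in an assay on isolated protein for inhibition of Intestinal-type alkaline phosphatase (Bos taurus), read by spectrophotometry, with stated times of 7 min and 15 min; a higher number here means a weaker inhibitor, a lower number a stronger inhibitor
- Compound 2 `CCCCCc1c(Br)c(=O)c2cc([N+](=O)[O-])ccc2n1Cc1ccc(OC)cc1`: 122000 nM in this assay
- Compound 3 `Cc1ccc(-c2[nH]c3ccc([N+](=O)[O-])cc3c(=O)c2Br)cc1`: 12100 nM in this assay

Among these three numbers compound 3 stands second highest. Its nearest neighbour is compound 1, reached by the step of a 5.0-fold higher number from compound 1 to compound 3 (0.70 log units; beyond the scatter); its furthest is compound 2, which shows a higher number still. The unmeasured compound 4 `CCCCCc1[nH]c2ccc([N+](=O)[O-])cc2c(=O)c1Br` differs from compound 3 in one place: pentyl in place of 4-methylphenyl on an aromatic carbon.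

For the measured compounds named here, one measured step bears directly on this change. Between compound 1 and compound 2 the same exchange on the same carbon of the shared core was made, and it gave a 50-fold higher number from compound 1 to compound 2 (1.70 log units; beyond the scatter), a large move toward weaker inhibition. Compound 3 carries a hydrogen on the ring nitrogen where compound 1 carries 4-methoxybenzyl, so the surroundings differ, and nothing measured shows whether the exchange behaves the same on the unsubstituted nitrogen. Even so, the only precedent points one way and by a wide margin.

Compound 4 is therefore expected to give a much higher number than compound 3 in this assay, a step of about a 41-fold higher number from compound 3 to compound 4 (1.62 log units; beyond the scatter), because of the step of a 50-fold higher number from compound 1 to compound 2 (1.70 log units; beyond the scatter) seen for the same change. The estimate for compound 4 is 500000 nM, within a range of 100000 nM to 2500000 nM.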

Compound 4, half-maximal inhibitory concentration: 3060 nM
The estimate for compound 4 lay 160-fold (2.21 log units) above the measured number, outside the stated range (below it).
By their numbers in this assay, from the lowest: compounds 1 and 4 (each within the scatter of the next); then compound 3; then compound 2.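

On the core with a hydrogen on the ring nitrogen, pentyl in place of 4-methylphenyl on this aromatic carbon next to the ring nitrogen does not weaken inhibition in this assay; it gives a 4.0-fold lower number from compound 3 to compound 4 (0.60 log units; beyond the scatter), so the direction of this exchange depends on what the ring nitrogen carries: the same change on two cores in this assay, a 50-fold higher number (1.70 log units; beyond the scatter) from compound 1 to compound 2 and a 4.0-fold lower number (0.60 log units; beyond the scatter) from compound 3 to compound 4, 200-fold (2.30 log units) apart, beyond the scatter of two such steps

The nitrogen change likewise depends on the group on the carbon, since with pentyl in place, hydrogen in place of 4-methoxybenzyl gives a 40-fold lower number from compound 2 to compound 4 (1.60 log units; beyond the scatter), opposite in direction to its effect with 4-methylphenyl: the same change on two cores in this assay, a 5.0-fold higher number (0.70 log units; beyond the scatter) from compound 1 to compound 3 and a 40-fold lower number (1.60 log units; beyond the scatter) from compound 2 to compound 4, 200-fold (2.30 log units) apart, beyond the scatter of two such steps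

The two places therefore do not contribute independently, and among these four compounds the high number of compound 2 belongs to the pairing of pentyl with 4-methoxybenzyl, not to either group alone.

The compounds shown leave open whether a shorter chain such as propyl, a longer chain such as octyl, or a branched chain such as isopentyl on this carbon would follow pentyl on either core. They also leave open whether a plain benzyl or a methyl on the ring nitrogen would behave like hydrogen or like 4-methoxybenzyl when paired with pentyl.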